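Notes on methyl additions in a cytotoxicity series

The source may hold more compounds than are shown below. What is called first, only, known or untested is meant among the compounds shown, and "the series" means these compounds.

Measured compounds:
compound 1 `O=C(Nc1ccc(Oc2ccnc3[nH]ccc23)c(F)c1)c1ccc(-c2ccccc2)cn1`, 4390 nM
compound 2 `Cc1ccc(-c2ccc(C(=O)Nc3ccc(Oc4ccnc5[nH]ccc45)c(F)c3)nc2)cc1`, 8020 nM
compound 3 `Cc1ccc(-c2ccnc(C(=O)Nc3ccc(Oc4ccnc5[nH]ccc45)c(F)c3)c2)cc1`, 8430 nM

In a functional assay on MCF7 cells (Homo sapiens) for cytotoxicity, read by MTT assay, with a stated time of 72 h (a higher number here means a weaker inhibitor, a lower number a stronger inhibitor), compound 1 gives 4390 nM. Compound 2 differs from compound 1 by methyl in place of hydrogen on an aromatic carbon, and the step is a 1.8-fold higher number from compound 1 to compound 2 (0.26 log units; within the scatter), so the two values are not separated by more than the scatter. Compound 3 carries a different core; the difference between the core of compound 3 and the core of compound 1 is not broken down here. In this assay compound 3 gives 8430 nM, which lies close to the value of compound 2 and within the scatter of the value of compound 1.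

Compound 4 `Cc1ccc(-c2ccnc(C(=O)Nc3ccc(Oc4ccnc5[nH]ccc45)c(F)c3)c2)c(C)c1` is not yet measured. It differs from compound 3 by methyl in place of hydrogen on an aromatic carbon. This is the same kind of change as that from compound 1 to compound 2, but not the same: there the entering methyl sits para to a large group, here it sits ortho to a large group and meta to a methyl group, and the change reads 4-methylphenyl to 2,4-dimethylphenyl rather than phenyl to 4-methylphenyl. Going by the values given here, the one measured example of this kind of change gave a step within the scatter, so a step of similar small size is expected from compound 3 to compound 4, namely a 1.3-fold higher number from compound 3 to compound 4 (0.12 log units; within the scatter). Among the compounds with values here, with only one precedent and a different place of substitution, the range is kept wide. Compound 4 is estimated at 11000 nM in this assay, expected between 5000 nM and 25000 nM.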

Compound 4, half-maximal inhibitory concentration: 6220 nM
Compound 4: middle estimate off by 1.8-fold (0.25 log units), on the high side; low and high end bracket the measured number.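

In this assay, going from 4-methylphenyl to 2,4-dimethylphenyl gives a 1.4-fold lower number from compound 3 to compound 4 (0.13 log units; within the scatter), so this methyl addition does not separate the two compounds. Set beside the earlier methyl addition, the new step does not differ from it by more than two such steps can scatter: the same change on two cores in this assay, a 1.8-fold higher number (0.26 log units; within the scatter) from compound 1 to compound 2 and a 1.4-fold lower number (0.13 log units; within the scatter) from compound 3 to compound 4, 2.5-fold (0.39 log units) apart, within the scatter of two such steps. Going by these compounds alone, on these two cores, methyl in place of hydrogen on an aromatic carbon therefore gives no step beyond the scatter, but that does not establish a rule for carrying the change between cores: there are only two examples, the methyl entering compound 4 sits ortho to a large group and meta to a methyl group while the one entering compound 2 sits elsewhere, and neither step has a direction that can be read.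

Still open, going by these compounds, is whether a group other than methyl on the outer phenyl ring, such as methoxy, trifluoromethyl, an amine or a carboxylic acid, would give a step beyond the scatter on either core. Also open, on these data alone, is whether a longer chain in that place would behave as methyl does in this assay, and whether the small methyl steps would hold in any other read-out.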